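The source may hold more compounds than are shown below. What is called first, only, known or untested is meant among the compounds shown, and "the series" means these compounds.

The shared core of compound 1 `CC1=C(SCCCO)C(=O)c2ccccc2C1=O` carries on its sulfur a saturated chain that ends in a hydroxy group, and in a functional assay on MKN-45 cells (Homo sapiens) for inhibition (a higher number here means a weaker inhibitor, a lower number a stronger inhibitor), compound 1 gives 6400 nM. Compound 2 `CC1=C(SCCCCO)C(=O)c2ccccc2C1=O` has that chain one carbon longer, and in this assay compound 2 gives 6780 nM. Compound 3 `CC1=C(SCCCCCCO)C(=O)c2ccccc2C1=O` carries the longest chain of the three. For compound 3 this assay reports no number but only a limit, > 10000 nM; this is the limit of > 10000 nM in this assay, at which 1 of the 3 values shown sits. The step of a 1.1-fold higher number from compound 1 to compound 2 (0.03 log units; within the scatter) lies within the scatter, and the steps of an at least 1.5-fold higher number from compound 1 to compound 3 (0.19 log units; that floor lies within the scatter) and an at least 1.4-fold higher number from compound 2 to compound 3 (0.16 log units; that floor lies within the scatter) can only be given as floors, each within the scatter. The change to compound 4 `CC1=C(SC(C)C(C)O)C(=O)c2ccccc2C1=O` is 2-hydroxy-1-methylpropyl in place of 6-hydroxyhexyl on a sulfur, so the chain becomes shorter and branched. With a shorter chain once more, compound 4 is expected to move back toward the numbers seen with the shorter chains, a step of an at least 1.4-fold lower number from compound 3 to compound 4 (0.15 log units; that floor lies within the scatter). Compound 4 is therefore estimated at 7000 nM, with a likely range from 2500 nM to 15000 nM.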

Compound 4, half-maximal inhibitory concentration: 5640 nM
Compound 4: middle estimate off by 1.2-fold (0.09 log units), on the high side, and the stated range covers the measured number.
By their numbers in this assay, from the lowest: compounds 4, 1 and 2 (each within the scatter of the next). At a limit, above all of these: compound 3.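

The branched 2-hydroxy-1-methylpropyl group on the sulfur gives a number in this assay that cannot be told apart from those of the two shorter unbranched chains, with a 1.2-fold lower number from compound 2 to compound 4 (0.08 log units; within the scatter) and a 1.1-fold lower number from compound 1 to compound 4 (0.05 log units; within the scatter). At this position, then, a branched chain bearing a hydroxy group sits level with the 3-hydroxypropyl and 4-hydroxybutyl chains among these compounds. Against the 6-hydroxyhexyl chain the comparison gives only a floor, an at least 1.7-fold lower number from compound 3 to compound 4 (0.24 log units; that floor lies within the scatter), so even compound 4 does not show that the longest chain differs, and compound 3 remains a limit: the limit of > 10000 nM in this assay, at which 1 of the 4 values shown sits.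

Still open, from the compounds shown here alone, is whether the hydroxy group matters at all, which a plain butyl chain, an amine or a carboxylic acid at the chain end would test. Also open, going by these compounds, is how a ring on the sulfur, such as a benzyl group, would compare.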